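The source may report more compounds than this note shows. Statements on the series, on what has been measured and on what is new or still open speak of the compounds shown alone.

Measured compounds:
compound 1, `CC(=O)N1N=C(c2ccc3ccccc3c2)OC1c1ccccc1`, 2.57 ug/mL
compound 2, `CC(=O)N1N=C(c2ccc3ccccc3c2)OC1c1ccccc1Br`, 6.98 ug/mL
compound 3, `CC(=O)N1N=C(c2ccc3ccccc3c2)OC1c1ccc(Br)cc1`, 4.68 ug/mL

All three numbers come from a functional assay on B16-F10 cells (Mus musculus) for antiproliferative activity, read by MTT assay, with a stated time of 48 h; a lower number here means a stronger inhibitor, a higher number a weaker inhibitor. Compound 2 shows the highest number of the three: the step of a 2.7-fold higher number from compound 1 to compound 2 (0.43 log units; beyond the scatter) lies beyond the scatter, whereas the gap a 1.5-fold lower number from compound 2 to compound 3 (0.17 log units; within the scatter) does not, so compound 2 and compound 3 cannot be told apart on these numbers.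

Compound 4, `CC(=O)N1N=C(c2ccc3ccccc3c2)OC1c1ccccc1[N+](=O)[O-]`, has not yet been measured. It differs from compound 2 in one place: nitro in place of bromo on an aromatic carbon. Among the compounds with values here, no measured step exchanges one group for another on an aromatic carbon; the steps at hand, a 2.7-fold higher number from compound 1 to compound 2 (0.43 log units; beyond the scatter) and a 1.8-fold higher number from compound 1 to compound 3 (0.26 log units; within the scatter), only put bromo in place of hydrogen, and both are modest at most. The set therefore holds no direct guide for nitro in place of bromo, and with nothing pointing in either direction the step is expected to remain within the scatter, a 1.2-fold lower number from compound 2 to compound 4 (0.07 log units; within the scatter).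

In this assay compound 4 is expected to give roughly 6 ug/mL, with the estimate spanning from 2.5 ug/mL to 15 ug/mL.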

Compound 4, half-maximal inhibitory concentration: 9.01 ug/mL
Compound 4: the middle estimate sits 1.5-fold (0.18 log units) below what was measured, within the range that was stated.
By their numbers in this assay, from the lowest: compounds 1, 3, 2 and 4 (each within the scatter of the next, the first and the last beyond it).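

In this assay, within the data shown here, this is the first exchange of one group for another on this aromatic carbon, ortho to a large group, and a 1.3-fold higher number from compound 2 to compound 4 (0.11 log units; within the scatter) means that compound 2 and compound 4 cannot be told apart, although the nitro group has more heavy atoms than the bromo it replaces. Against the parent with hydrogen at this place, a 3.5-fold higher number from compound 1 to compound 4 (0.54 log units; beyond the scatter) lies beyond the scatter, so among compounds 1, 2 and 4 both substituents give a modestly higher number than hydrogen; this covers only these two groups at this one place. The other bromo compound does not separate from the new one either, since a 1.9-fold higher number from compound 3 to compound 4 (0.28 log units; within the scatter) stays within the scatter.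

Nothing shown here gives a reason for these numbers. From the compounds shown here alone, it remains open whether an amine or a carboxylic acid on this same aromatic carbon would match the bromo and nitro compounds or return to the number of compound 1, and whether a nitro group placed where compound 3 carries its bromo would differ from compound 4.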